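A few compounds are considered here, and "the series" means these few. Any claim that something is new, unique, unknown or untested is made for them only; others in the source may bear on it.

Measured in (a functional assay on A549 cells (Homo sapiens) for antiproliferative activity, read by XTT assay, with a stated time of 72 h; a higher number here means a weaker inhibitor, a lower number a stronger inhibitor):

- Compound 1 `C=C(C)CC[C@]1(C)C2=CCC[C@](C)(C[C@H](O)c3ccoc3)[C@H]2CC[C@H]1C` gives 34000 nM
- Compound 2 `C=C(C)CC[C@]1(C)C2=CCC[C@](C)(C[C@@H](O)C3=CC(=O)OC3O)[C@H]2CC[C@H]1C` gives 4400 nM
- Compound 3 `C=C(C)CCC[C@]1(C)C2=CCC[C@](C)(C[C@@H](O)c3ccoc3)[C@H]2CC[C@H]1C` gives 66000 nM

Compound 3 lies within the scatter of compound 1, and its number is higher than that of compound 2 by more than the scatter. Compound 4 `C=C(C)CC[C@]1(C)C2=CCC[C@](C)(C[C@@H](O)c3ccoc3)[C@H]2CC[C@H]1C` has a shorter chain (1-methylethenyl in place of 2-methylprop-2-en-1-yl on a saturated chain carbon, two bonds along the chain from a saturated ring carbon), with 1-methylethenyl in place of 2-methylprop-2-en-1-yl. Among the measured compounds shown here, the only measured step (a 7.7-fold lower number from compound 1 to compound 2 (0.89 log units; beyond the scatter)) concerns a different group and does not bear on this change. Compound 1 (34000 nM) carries the chain of compound 4 and differs from it only in spatial arrangement at one carbon, so little movement is anticipated in this assay. The expected step is small (a 1.5-fold lower number from compound 3 to compound 4 (0.17 log units; within the scatter)), not beyond the scatter. The estimate for compound 4 is 45000 nM, with an expected range from 20000 nM to 100000 nM.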

Compound 4, half-maximal inhibitory concentration: 34000 nM
Compound 4: middle estimate off by 1.3-fold (0.12 log units), on the high side; low and high end bracket the measured number.
By their numbers in this assay, from the lowest: compound 2; then compounds 1, 4 and 3 (each within the scatter of the next).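

In this assay, placing 1-methylethenyl in place of 2-methylprop-2-en-1-yl gives a 1.9-fold lower number from compound 3 to compound 4 (0.29 log units; within the scatter) and so does not separate these two chains. The five-membered non-aromatic ring group does separate compounds, with a 7.7-fold higher number from compound 2 to compound 4 (0.89 log units; beyond the scatter) for its replacement by the five-membered aromatic ring group. The drawn configuration at one saturated chain carbon also does not separate compounds, with no change at the digits printed from compound 1 to compound 4 (within the scatter), and this pair isolates that single feature: the fact that compounds 1 and 4 differ only in the configuration as drawn.

Going by these compounds, whether an amine at the end of this chain would shift the number remains open. So does whether configuration matters when the five-membered non-aromatic ring group is present.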